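A few compounds are considered here, and "the series" means these few. Any claim that something is new, unique, unknown or untested is made for them only; others in the source may bear on it.

Compound 2, `CC(C1=C(CCN2CCCCC2)Cc2ccccc21)c1ccccn1`, gives 2340 nM in an assay on CHO-K1 cells for binding affinity to muscarinic acetylcholine receptor M5 (Homo sapiens); on this read-out lower numbers stand for stronger inhibition and higher numbers for weaker inhibition. Going by the values given here, of the two compounds measured so far it carries the highest number; compound 1, `CC(C1=C(CCN(C)C)Cc2ccc(Cl)cc21)c1ccccn1`, gives 912 nM in this assay, and the gap between the two lies beyond the usual scatter. Compound 3, `CC(C1=C(CCN(C)C(C)C)Cc2ccccc21)c1ccccn1`, differs from compound 2 by isopropyl(methyl)amino in place of piperidin-1-yl on a saturated chain carbon, two bonds along the chain from a double-bonded ring carbon. Among the compounds with values here, no measured pair shows this change on its own, so any expectation rests on the two values alone. A small step toward a lower number is expected, a 1.6-fold lower number from compound 2 to compound 3 (0.19 log units; within the scatter), quite possibly within the scatter. Compound 3 is therefore estimated at 1500 nM, with a range from 500 nM to 5000 nM.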

Compound 3, inhibition constant: 2190 nM
The estimate for compound 3 lay 1.5-fold (0.16 log units) below the measured number; low and high end bracket the measured number.
By their numbers in this assay, from the lowest: compound 1; then compounds 3 and 2 (each within the scatter of the next).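

In this assay, isopropyl(methyl)amino in place of piperidin-1-yl gives a 1.1-fold lower number from compound 2 to compound 3 (0.03 log units; within the scatter) and so stays within the scatter. At this saturated chain carbon, then, the ring of piperidin-1-yl can be exchanged for the open isopropyl(methyl)amino group, with its one heavy atom fewer, without a readable shift in the number. From the compounds shown here alone, whether a primary amine or a carboxylic acid in this place, or a longer chain in place of the 2-(isopropyl(methyl)amino)ethyl group, would shift the number stays open. Nothing at hand offers an explanation for this result.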